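The source may hold more compounds than are shown below. What is called first, only, known or untested is meant among the compounds shown, and "the series" means these compounds.

Measured so far:
- compound 1 `COc1ccc(N/C=C\C(=O)c2nc(-c3ccc(C(F)(F)F)cc3)n3ccccc23)cc1OC` — > 30000 nM in a functional assay on MDA-MB-231 cells (Homo sapiens) for cytotoxicity, read by MTT assay, with a stated time of 48 h; a lower number here means a stronger inhibitor, a higher number a weaker inhibitor
- compound 2 `COc1ccc(N/C=C\C(=O)c2nc(-c3ccccc3)n3ccccc23)cc1` — 28300 nM
- compound 3 `O=C(/C=C\Nc1cnc2ccccc2c1)c1nc(-c2ccc(C(F)(F)F)cc2)n2ccccc12` — > 30000 nM

Compound 3 sits at a limit of this assay, not at a number. Compound 1 likewise sits at a limit. Compound 2 gives a number, and that number lies close to the limit at which the others stop; the limit of > 30000 nM in this assay, at which 2 of the 3 values shown sit, is where the series stands so far. Among the measured compounds shown here, the one step that joins two measured compounds, a step that the two limits leave unreadable from compound 1 to compound 3, cannot be read in size, since both ends are limits.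

Compound 4 `COc1ccc(N/C=C\C(=O)c2nc(-c3ccc(C(F)(F)F)cc3)n3ccccc23)cc1` differs from compound 3 in one place: 4-methoxyphenyl in place of quinolin-3-yl on an amine nitrogen. For the measured compounds named here, no measured step bears on this change directly. Compound 2 carries the same (4-methoxyphenyl)amino group as compound 4, on a core that differs in the absence of the trifluoromethyl group, and it gives a value near the limit. Taking that together with the limits at compound 1 and compound 3, compound 4 is expected to remain weak in this assay, at about 30000 nM (range 12000 nM to 90000 nM). The step from compound 3 to compound 4 is therefore estimated as a number no higher from compound 3 to compound 4 (the limit leaves the size open), with a fair chance that only a limit is reported again.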

Compound 4, half-maximal inhibitory concentration: > 30000 nM
Compound 4: a limit, no number; the forecaster's own chance of this, stated with the estimate: 55%; the middle value sits exactly at the limit.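

In this assay compound 4 gives a limit, not a number, so 4-methoxyphenyl in place of quinolin-3-yl on the amine nitrogen yields no readable value here, and the steps to compound 4 from compound 1 and compound 3 cannot be read. Among the compounds shown here, the one step with a readable bound, trifluoromethyl in place of hydrogen on an aromatic carbon, is an at least 1.0-fold higher number from compound 2 to compound 4 (0.02 log units; that floor lies within the scatter), so it shows no change beyond the scatter, though a larger true step is not excluded. The series now stands mostly at one limit: the limit of > 30000 nM in this assay, at which 3 of the 4 values shown sit.

Going by these compounds, whether any group on this amine nitrogen gives a value well clear of that limit remains open. Also open, on these data alone, is what a carboxylic acid or a dimethylamino group would give in place of trifluoromethyl on the aromatic carbon.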